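Chloro to ethyl on the outer ring: expected outcome

The source may report more compounds than this note shows. Statements on the series, on what has been measured and on what is new or still open speak of the compounds shown alone.

For the measured compounds named here, compound 1 `O=S(=O)(Nc1ccc2oc(-c3ccccc3)nc2c1)c1ccc(Cl)cc1` is one of two compounds measured so far. In an assay on isolated protein for inhibition of malate dehydrogenase, mitochondrial (Sus scrofa), with stated times of 45 min and 30 min (a higher number here means a weaker inhibitor, a lower number a stronger inhibitor), compound 1 gives > 63000 nM, which is a limit of the assay and not a number. Compound 2 `O=S(=O)(Nc1ccc(-c2nc3ccccc3o2)cc1)c1ccccc1O` stands at the same limit: in this assay compound 2 gives > 63000 nM, again a limit rather than a number. Going by the values given here, both measured values thus rest at the limit of > 63000 nM in this assay, at which 2 of the 2 values shown sit, so no step between measured compounds can be counted, and of compound 1 and compound 2 only this can be said: neither shows measurable inhibition.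

Compound 3 `CCc1ccc(S(=O)(=O)Nc2ccc3oc(-c4ccccc4)nc3c2)cc1` is not yet measured. It differs from compound 1 by ethyl in place of chloro on an aromatic carbon, the shared core of compound 1 being kept and one substituent on the outer ring exchanged. With both measured compounds at a limit, the data give no ground to expect a gain from this change. The step that the limit leaves unreadable from compound 1 to compound 3 is expected to be none beyond the scatter, most likely ending in another limit. Compound 3 is estimated at 100000 nM in this assay, with a range from 40000 nM to 300000 nM.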

Compound 3, half-maximal inhibitory concentration: > 63000 nM
Compound 3: a limit, no number; the forecaster's own chance of this, stated with the estimate: 85%; the middle value lies beyond the limit too.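

In this assay compound 3 gives > 63000 nM as a limit of the assay and not a number. For the compounds shown here, compound 1 also stands at a limit, so no step between compound 1 and compound 3 can be read. The compounds shown leave open whether any substituent on the outer ring gives a number in this assay at all.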